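The compounds below may be only part of what the source reports. "The series", "measured", "known", "first", "only" and "open" are said of these compounds alone.

For the measured compounds named here, in a functional assay on MCF7 cells (Homo sapiens) for cytotoxicity, read by WST assay, with a stated time of 72 h (on this read-out higher numbers stand for weaker inhibition and lower numbers for stronger inhibition), compound 3 (`O=C1Nc2c(ccc(F)c2F)C1(c1ccc(O)cc1)C1CCCCCC1`) gives 1.2 nM, the lowest number so far. Compound 1 (`O=C1Nc2c(ccc(F)c2F)C1(c1ccc(O)cc1)c1ccc(F)cc1`) gives 2.6 nM and compound 2 (`CCOc1ccc(C2(c3ccc(O)cc3)C(=O)Nc3c2ccc(F)c3F)cc1`) gives 11 nM. Compound 4 (`O=C1Nc2c(ccc(F)c2F)C1(Cc1ccccc1)c1ccc(O)cc1`) carries benzyl in place of cycloheptyl on a saturated ring carbon. Two measured steps at that carbon bear on this change: a 2.2-fold lower number from compound 1 to compound 3 (0.34 log units; beyond the scatter) with cycloheptyl in place of 4-fluorophenyl, and a 9.2-fold lower number from compound 2 to compound 3 (0.96 log units; beyond the scatter) with cycloheptyl in place of 4-ethoxyphenyl. Neither step tests benzyl itself, but both groups replaced there hold an aromatic ring, as benzyl does. A modest step to a higher number is therefore expected in this assay. The expected size is a 2.9-fold higher number from compound 3 to compound 4 (0.46 log units; beyond the scatter). For compound 4 the estimated value is 3.5 nM, with an expected range of 1.2 nM to 10 nM.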

Compound 4, half-maximal inhibitory concentration: > 1000 nM
Compound 4 was reported as a limit (the forecaster's own chance of this, stated with the estimate: 2%); at least 280-fold (2.45 log units) between middle value and limit.
By their numbers in this assay, from the lowest: compound 3; then compound 1; then compound 2. At a limit, above all of these: compound 4.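

In this assay compound 4 stands only as a limit, not a number: the limit of > 1000 nM in this assay, at which 1 of the 4 values shown sits. This carbon tolerates 4-fluorophenyl, 4-ethoxyphenyl and cycloheptyl, but not benzyl: an at least 830-fold higher number from compound 3 to compound 4 (2.92 log units; beyond the scatter), an at least 380-fold higher number from compound 1 to compound 4 (2.58 log units; beyond the scatter) and an at least 90-fold higher number from compound 2 to compound 4 (1.95 log units; beyond the scatter). Benzyl and cycloheptyl both count 7 heavy atoms, and compound 1 and compound 2 also hold an aromatic ring, so neither that count nor an aromatic ring alone tracks the loss.

From the compounds shown here alone, whether the loss follows the chain link of benzyl or the combination of link and aromatic ring remains open; cyclohexylmethyl or phenethyl at this carbon would bear on that.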